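Pyridin-3-yl to Pyridin-4-yl: Expecting a Small Step

A few compounds are considered here, and "the series" means these few. Any claim that something is new, unique, unknown or untested is made for them only; others in the source may bear on it.

Compound 1, `CCN(CC)C(=O)c1ccccc1OCC1=NCCN1`, and compound 2, `c1cncc(-c2ccccc2OCC2=NCCN2)c1`, share a core and differ only in the group attached to it. In a functional assay for activation of Alpha-1B adrenergic receptor (Homo sapiens), read by calcium flux (a higher number here means that more compound is needed for the effect, a lower number that less compound is needed), compound 1 gives no number, only a limit of < 5020 nM. One of the two values shown is such a limit (the limit of < 5020 nM in this assay, at which 1 of the 2 values shown sits). In this assay, among the measured compounds shown here, compound 2 gives 79.4 nM, the only actual number among the compounds measured so far, so there is nothing to rank it against.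

Compound 3, `c1ccc(-c2ccncc2)c(OCC2=NCCN2)c1`, is built from the same atoms as compound 2, joined differently: pyridin-4-yl in place of pyridin-3-yl on an aromatic carbon. For the measured compounds named here, no measured pair shows what such a swap does here. The expectation is a step of modest size, if any, leaning toward more compound being needed, but possibly not beyond the usual scatter. For compound 3 the half-maximal effective concentration in this assay is estimated at 160 nM, with a range from 40 nM to 650 nM. That estimate means an expected step of a 2.0-fold higher number from compound 2 to compound 3 (0.30 log units; within the scatter).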

Compound 3, half-maximal effective concentration: < 100000 nM
Compound 3: only a limit was reported; the forecaster's own chance of this, stated with the estimate: 10%; the middle value is on the limit's open side.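

In this assay compound 3 gives < 100000 nM as a limit, not a number. Among the compounds shown here, no step from compound 2 to compound 3 can be read. The compounds shown leave open how far pyridin-4-yl in place of pyridin-3-yl on an aromatic carbon really shifts the half-maximal effective concentration.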